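Oxazole for tolyl on the outer amide carbonyl

The compounds below may be only part of what the source reports. "The series", "measured", "known", "first", "only" and "open" are said of these compounds alone.

The series pairs a shared bis-amide core with varied terminal groups. Compound 3 `Cc1ccc(C(=O)Nc2cccc(NC(=O)COc3ccc4c(=O)ccoc4c3)c2)cc1` gives 183 nM in an assay on isolated protein for inhibition of Rho-associated protein kinase 1 (Homo sapiens), read by scintillation counting, radiometric assay and 33P incorporation, with a stated time of 40 min, in the presence of a further agent that is not named here (a lower number here means a stronger inhibitor, a higher number a weaker inhibitor), the lowest of the two numbers recorded. Compound 1 `CC(=O)c1ccc(OCC(=O)Nc2cccc(NC(=O)c3ccc(N(C)C)cc3)c2)cc1F` gives 445 nM in this assay, a higher number than compound 3, and the gap between the two lies beyond the usual scatter. Compound 2 `Cc1coc2cc(OCC(=O)Nc3cccc(NC(=O)c4ccc(N(C)C)cc4)c3)ccc2c1=O` reaches only a limit in this assay, > 10000 nM, and that limit is the limit of > 10000 nM in this assay, at which 1 of the 3 values shown sits. For the measured compounds named here, no two measured compounds differ in a single place, so no measured step is available to calibrate the change now considered.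

Compound 4 `Cc1cc(C(=O)Nc2cccc(NC(=O)COc3ccc4c(=O)ccoc4c3)c2)no1` is the unmeasured partner of compound 3; the difference between them is 5-methyl-1,2-oxazol-3-yl in place of 4-methylphenyl on a carbonyl carbon. With no measured step of this kind in hand, the expectation rests on the value of compound 3 alone. The step from compound 3 to compound 4 is expected to be small, most likely a modest rise in the number, a 2.2-fold higher number from compound 3 to compound 4 (0.34 log units; beyond the scatter), with a fair chance it falls within the scatter. Compound 4 is therefore estimated at 400 nM in this assay, with a range from 120 nM to 1500 nM.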

Compound 4, half-maximal inhibitory concentration: 68 nM
Compound 4: the middle estimate sits 5.9-fold (0.77 log units) above what was measured; measured number below the stated range.
By their numbers in this assay, from the lowest: compound 4; then compound 3; then compound 1. At a limit, above all of these: compound 2.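

In this assay, the group on this carbonyl carbon can be changed without loss: 5-methyl-1,2-oxazol-3-yl in place of 4-methylphenyl gives a 2.7-fold lower number from compound 3 to compound 4 (0.43 log units; beyond the scatter). For the compounds shown here, as the only measured single-place change, this step shows that the number responds to the ring held at this position, and that a ring of carbon only is not required there: a five-membered aromatic ring with 2 hetero atoms and 2 hydrogen-bond acceptors gives the lower number. Nothing measured here bears on the reason for this step, which stands as an observation without an explanation.

Ring size and hetero atoms change together in this one step, so their separate contributions cannot be told apart, and the part played by the methyl group on the new ring also remains unknown. Still open, on these data alone, are how the unsubstituted 1,2-oxazol-3-yl, a pyridine ring or a longer alkyl chain on the oxazole would read at this position, and whether the same exchange would give a similar step with the other terminal group of compound 3 replaced.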